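A Longer Chain at the Limit of the Assay

This account rests on a few compounds, and the source may have more. Where it says the series, first, only, none or still open, it means among the compounds named here.

Compound 1 `O=C(OCCO)OCCc1ccc(O)c(O)c1`, compound 2 `O=C(OCCCCO)OCCc1ccc(O)c(O)c1`, compound 3 `O=C(OCCCCCCO)OCCc1ccc(O)c(O)c1` and compound 4 `O=C(OCCCCCCCCO)OCCc1ccc(O)c(O)c1` share one core. In an ADME assay on MRC5 cells (Homo sapiens) for inhibition, read by MTT assay, with a stated time of 72 h (on this read-out higher numbers stand for weaker inhibition and lower numbers for stronger inhibition), compound 1 reads "not determined" (no result reported), and compound 2 reads "not determined" (no result reported). In this assay, compound 3 gives > 50000 nM, which is a limit of the assay and not a number. Compound 4 carries 2-hydroxyethyl in place of hydroxy on a saturated chain carbon, six bonds along the chain from an oxygen next to a carbonyl group. Within the data shown here, no measured step exists to guide a forecast, so only a small shift towards stronger inhibition, perhaps none beyond the scatter, is expected in this assay. The estimated step is an at least 1.1-fold lower number from compound 3 to compound 4 (0.04 log units; that floor lies within the scatter). For compound 4 the expected value is 45000 nM, within an estimated range of 15000 nM to 100000 nM.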

Compound 4, half-maximal inhibitory concentration: > 50000 nM
Compound 4: no number, only a limit; the forecaster's own chance of this, stated with the estimate: 60%; middle value at least 1.1-fold (0.04 log units) from the limit.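

No step can be read between compound 3 and compound 4, because both values are limits of the assay and not numbers: the limit of > 50000 nM in this assay, at which 2 of the 4 values shown sit. The compounds shown leave open whether this chain change alters inhibition in this assay at all.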